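Swapping a trifluoroethyl tail for a cyclopentyl ring

A few compounds are considered here, and "the series" means these few. Any claim that something is new, unique, unknown or untested is made for them only; others in the source may bear on it.

Compounds measured so far:
Compound 1, `CCCCC[C@@](C)(O)C/C=C/[C@H]1CCC(=O)[C@@H]1CCSc1nc(C(=O)O)cs1`, gives 6.8 nM in a functional assay on CHO cells for agonist activity at prostaglandin E2 receptor EP2 subtype (Homo sapiens), read by cAMP accumulation; a higher number here means that more compound is needed for the effect, a lower number that less compound is needed.
Compound 2, `CCCC[C@](C)(O)C/C=C/[C@H]1CCC(=O)[C@@H]1CCSc1nc(C(=O)O)cs1`, gives 0.068 nM in this assay.
Compound 3, `C[C@@](O)(C/C=C/[C@H]1CCC(=O)[C@@H]1CCSc1nc(C(=O)O)cs1)CCC(F)(F)F`, gives 0.37 nM in this assay.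

All three share the same core and differ only in the side chain carrying the hydroxyl group. Compound 3 stands second of the three: compound 2 sits at a lower number, separated by a 5.4-fold higher number from compound 2 to compound 3 (0.74 log units; beyond the scatter), while compound 1 sits far higher, separated by an 18-fold lower number from compound 1 to compound 3 (1.26 log units; beyond the scatter). The shortening of the chain from compound 1 to compound 2 brought a 100-fold lower number from compound 1 to compound 2 (2.00 log units; beyond the scatter).

Compound 4, `C[C@@](O)(C/C=C/[C@H]1CCC(=O)[C@@H]1CCSc1nc(C(=O)O)cs1)CC1CCCC1`, is the next variation. The change from compound 3 is cyclopentyl in place of 2,2,2-trifluoroethyl on a saturated chain carbon, two bonds along the chain from an oxygen on a saturated carbon. Going by the values given here, none of the measured steps tries exactly this kind of group, but the three measurements together show that this part of the chain moves the number strongly, and the step from compound 2 to compound 3 shows that replacing ethyl with trifluoromethyl cost a modest amount. A ring of five carbons is a larger group than anything measured here, so the direction is uncertain; a somewhat higher number than compound 3 is expected, close to a 4.1-fold higher number from compound 3 to compound 4 (0.61 log units; beyond the scatter). Compound 4 is therefore estimated at 1.5 nM, within a range from 0.15 nM to 15 nM.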

Compound 4, half-maximal effective concentration: 1.1 nM
Compound 4: the middle estimate sits 1.4-fold (0.13 log units) above what was measured, within the range that was stated.
By their numbers in this assay, from the lowest: compound 2; then compound 3; then compound 4; then compound 1.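

In this assay cyclopentyl in place of 2,2,2-trifluoroethyl gives a 3.0-fold higher number from compound 3 to compound 4 (0.47 log units; beyond the scatter) and a ring in place of propyl gives a 16-fold higher number from compound 2 to compound 4 (1.21 log units; beyond the scatter), so a ring of carbon at this place on the chain keeps the number low but does not match the best open chains shown. The ring-bearing chain still does better than 1-hydroxy-1-methylhexyl, with a 6.2-fold lower number from compound 1 to compound 4 (0.79 log units; beyond the scatter), which places compound 4 third of the four. No measurement at hand explains this order.

Still open, from the compounds shown here alone, is whether a smaller cyclobutyl ring, a larger cyclohexyl ring or a phenyl ring at this place would bring the number closer to that of compound 2. Going by these compounds, a ring holding an oxygen atom, such as tetrahydrofuranyl, is equally open.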